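Sulfamoyl carbamates and ureas: swapping the sulfonyl substituent

The compounds below may be only part of what the source reports. "The series", "measured", "known", "first", "only" and "open" are said of these compounds alone.

Compound 3 `CC(C)c1cccc(C(C)C)c1OC(=O)NS(=O)(=O)N1CCc2ccccc21` gives 43000 nM in an assay on liver for inhibition of sterol O-acyltransferase 1 (Rattus norvegicus), using microsomes (on this read-out higher numbers stand for weaker inhibition and lower numbers for stronger inhibition), the highest of the three numbers in hand. The urea compound 1 `CC(C)c1cccc(C(C)C)c1NC(=O)NS(=O)(=O)N1CCCC1` gives 15000 nM in this assay, and compound 2 `CCCN(CCC)S(=O)(=O)NC(=O)Nc1c(C(C)C)cccc1C(C)C` gives 1100 nM. Compound 4 `CC(C)c1cccc(C(C)C)c1OC(=O)NS(=O)(=O)Oc1c(F)cccc1F` carries 2,6-difluorophenoxy in place of 2,3-dihydro-1H-indol-1-yl on a sulfonyl sulfur. Among the compounds with values here, the only measured step at the sulfonyl sulfur is a 14-fold lower number from compound 1 to compound 2 (1.13 log units; beyond the scatter), which shows that exchanging the group on that sulfur can move this assay by a large margin; no measured pair exchanges a ring nitrogen for a phenoxy oxygen there, so the direction is open. Compound 4 is therefore estimated at 25000 nM (range 6000 nM to 100000 nM), a step of a 1.7-fold lower number from compound 3 to compound 4 (0.24 log units; within the scatter), not expected to clear the scatter with confidence.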

Compound 4, half-maximal inhibitory concentration: 38000 nM
The estimate for compound 4 lay 1.5-fold (0.18 log units) below the measured number; the measured number falls inside the stated range.
By their numbers in this assay, from the lowest: compound 2; then compound 1; then compounds 4 and 3 (each within the scatter of the next).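

In this assay, exchanging 2,3-dihydro-1H-indol-1-yl for 2,6-difluorophenoxy on the sulfonyl sulfur gives a 1.1-fold lower number from compound 3 to compound 4 (0.05 log units; within the scatter), so a ring nitrogen and a phenoxy oxygen on that sulfur cannot be told apart in this pair. Exchange at this position therefore does not always give a step as large as a 14-fold lower number from compound 1 to compound 2 (1.13 log units; beyond the scatter). Nothing in hand explains this pair.

Going by these compounds, whether dipropylamino on the core of compound 3 would match its effect on the core of compound 1 remains open. So does the outcome with dibutylamino or unsubstituted phenoxy on that sulfur.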